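Hydrogen in Place of Chloro: From Compound 1 to Compound 4

A few compounds are considered here, and "the series" means these few. Any claim that something is new, unique, unknown or untested is made for them only; others in the source may bear on it.

The series was examined in a functional assay on UACC-62 cells (Homo sapiens) for cytotoxicity, read by sulforhodamine B assay, with a stated time of 48 h; on this read-out lower numbers stand for stronger inhibition of growth and higher numbers for weaker inhibition of growth. Compound 1 `ClCc1cccc(Cn2cnc3c(Cl)nc(Cl)nc32)c1` gives 1860 nM in this assay. Compound 2 `ClCc1ccccc1Cn1cnc2ncnc(Cl)c21` gives 1860 nM, which is level with compound 1 at the digits recorded, and together these two hold the lowest numbers of the three. Compound 3 `ClCc1ccccc1Cn1cnc2c(Cl)ncnc21` gives 3310 nM, the furthest of the measured values from compound 1, though the gap stays within the usual scatter of repeated measurements. Within the data shown here, no pair of these three compounds differs in only one place, so no single-point step has been measured.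

Compound 4 `ClCc1cccc(Cn2cnc3c(Cl)ncnc32)c1` has not yet been measured in this assay. It differs from compound 1 by hydrogen in place of chloro on an aromatic carbon. Compounds 2 and 3 each carry a single chloro group on the shared core, and their values sit close to that of compound 1, so the three measured numbers leave little room for a large movement in either direction. The step from compound 1 to compound 4 is therefore expected to be small, and most likely within the scatter, as a 1.3-fold higher number from compound 1 to compound 4 (0.13 log units; within the scatter). Compound 4 is estimated at 2500 nM in this assay, with a range from 1000 nM to 6500 nM.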

Compound 4, concentration for 50% growth inhibition: 1820 nM
Compound 4: middle estimate off by 1.4-fold (0.14 log units), on the high side; low and high end bracket the measured number.
By their numbers in this assay, from the lowest: compounds 4, 1, 2 and 3 (each within the scatter of the next).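

Among these compounds, the exchange of chloro for hydrogen on the aromatic carbon between two ring nitrogen atoms gives the first single-place step, and in this assay it is a 1.0-fold lower number from compound 1 to compound 4 (0.01 log units; within the scatter). The three earlier compounds could not show this, since no two of them differ in only one place; the step now shows that, in this assay and with the rest of compound 1 unchanged, the chloro group at this carbon can be lost without a change in the number beyond the scatter. Nothing available accounts for this outcome, so the result stands as an observation without an explanation.

The compounds shown leave open whether this carbon accepts anything other than chloro or hydrogen, for instance an amine or a methoxy group, and whether such a group would move the number beyond the scatter. Among the compounds shown here, they also leave open what a change at the chloro group that remains on the shared core of compound 4 would do, as no step at that place is available.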